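From fluoro to nitro on compound 2

The source may hold more compounds than are shown below. What is called first, only, known or untested is meant among the compounds shown, and "the series" means these compounds.

In a functional assay on HL-60 cells (Homo sapiens) for inhibition, read by CCK-8 assay, with a stated time of 48 h (on this read-out lower numbers stand for stronger inhibition and higher numbers for weaker inhibition), compound 2 `O=C(Nc1ccc(F)cc1)N1CCN(S(=O)(=O)c2sccc2-c2ccccc2Oc2ccc(O)c(O)c2)CC1` gives 8100 nM and lies within the usual scatter of compound 3 `O=[N+]([O-])c1cccc(NC(=S)NCCNS(=O)(=O)c2ccc(-c3ccccc3OCc3cccc(O)c3)s2)c1` at 11400 nM so neither can be ranked ahead. Compound 1 `COc1ccc(Oc2ccc([N+](=O)[O-])cc2-c2ccsc2S(=O)(=O)N2CCN(C(=S)Nc3ccc([N+](=O)[O-])cc3)CC2)cc1OC` returns only a limit, not a number (> 50000 nM).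

Compound 4 `O=C(Nc1ccc([N+](=O)[O-])cc1)N1CCN(S(=O)(=O)c2sccc2-c2ccccc2Oc2ccc(O)c(O)c2)CC1` keeps the rest of compound 2 but swaps 4-fluorophenyl for 4-nitrophenyl, with nitro in place of fluoro on an aromatic carbon, para to a large group (nitro in place of fluoro on an aromatic carbon). For the measured compounds named here, no measured pair of compounds shows this swap, so no shift beyond the scatter is expected in this assay for it. The expected change (a 1.2-fold higher number from compound 2 to compound 4 (0.09 log units; within the scatter)) is therefore small. Compound 4 is estimated at 10000 nM (expected range 3500 nM to 35000 nM).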

Compound 4, half-maximal inhibitory concentration: 4900 nM
Beside the measured number, compound 4's estimate is 2.0-fold (0.31 log units) above it, within the range that was stated.
By their numbers in this assay, from the lowest: compounds 4, 2 and 3 (each within the scatter of the next, the first and the last beyond it). At a limit, above all of these: compound 1.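

Nitro in place of fluoro on the aromatic carbon para to a large group gives a 1.7-fold lower number from compound 2 to compound 4 (0.22 log units; within the scatter) in this assay, and this is the first comparison here in which only one place differs. The position therefore accepts nitro, which brings hydrogen-bond acceptors that fluoro lacks, with no shift beyond the scatter. Nothing shown here gives a cause for this small step.

From the compounds shown here alone, whether an amine or a carboxylic acid at this position would shift the number beyond the scatter remains open.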